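The source may hold more compounds than are shown below. What is called first, only, known or untested is meant among the compounds shown, and "the series" means these compounds.

Working notes on the series. In a functional assay on Huh-5-2 cells (Homo sapiens) for cytotoxicity, read by microscopy (on this read-out lower numbers stand for higher toxicity in this test and higher numbers for lower toxicity in this test), compound 1 (`CC(=O)OC[C@H]1O[C@@H](n2c(SCc3cc4cc(Br)ccc4oc3=O)nc3cncnc32)[C@H](O)[C@@H]1O`) gives 31000 nM and compound 2 (`CC(=O)OC[C@H]1O[C@@H](n2c(SCc3cc4cc(Br)cc(Br)c4oc3=O)nc3cncnc32)[C@H](O)[C@@H]1O`) gives 7000 nM, the lower of the two numbers. Compound 2 therefore stands at the more toxic end of this small set.

Compound 3 (`O=c1oc2c(Br)cc(Br)cc2cc1CSc1nc2cncnc2n1[C@@H]1O[C@H](CO)[C@@H](O)[C@H]1O`) differs from compound 2 by hydrogen in place of acetyl on an oxygen on a saturated carbon. This is hydrogen in place of acetyl on an oxygen on a saturated carbon, or acetoxymethyl to hydroxymethyl when cut one bond further out.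

Going by the values given here, the only measured step is a 4.4-fold lower number from compound 1 to compound 2 (0.65 log units; beyond the scatter). It is modest and beyond the scatter, but it is bromo in place of hydrogen on an aromatic carbon, so it is a different change. Among the compounds with values here, no measured pair removes the acetyl, which leaves the direction poorly supported and the size guided only by that one modest step.

A modest move towards a higher number in this assay is the working expectation, and the expected step is a 2.1-fold higher number from compound 2 to compound 3 (0.33 log units; beyond the scatter). For compound 3 the estimated value is 15000 nM, with an expected range of 5000 nM to 45000 nM.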

Compound 3, half-maximal cytotoxic concentration: 36000 nM
Compound 3: middle estimate off by 2.4-fold (0.38 log units), on the low side; the measured number falls inside the stated range.
By their numbers in this assay, from the lowest: compound 2; then compounds 1 and 3 (each within the scatter of the next).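

In this assay, going by these compounds alone, the change from acetoxymethyl to hydroxymethyl gives a 5.1-fold higher number from compound 2 to compound 3 (0.71 log units; beyond the scatter), the only step at this position, and it shows that the number responds to the group on this oxygen on a saturated carbon as well as to the bromo on the aromatic carbon. The number moves towards lower toxicity in this test here, whereas a 4.4-fold lower number from compound 1 to compound 2 (0.65 log units; beyond the scatter) moves it towards higher toxicity, so the two modest steps at these different places run in opposite directions on the read-out. Nothing at hand accounts for the move on loss of the acetyl.

As far as these compounds go, whether the same loss of acetyl gives a step of similar size and direction without the added bromo of compound 2, as on the core of compound 1, remains open, as a single pair cannot show whether the two changes act independently. Also open, from the compounds shown here alone, is how other groups on this oxygen would read in this test, such as a longer acyl chain like butanoyl or a methyl ether, or an amine in place of the hydroxy.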